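From fluoro to methyl in a solubility series

The compounds below may be only part of what the source reports. "The series", "measured", "known", "first", "only" and "open" are said of these compounds alone.

Values measured so far in a physicochemical assay for solubility, read by spectrophotometry, in phosphate buffer, with a stated time of 18 h, at pH 7.4 (on this read-out lower numbers stand for lower solubility and higher numbers for higher solubility), are
compound 1 `CCc1ccc(-c2nc3c(c(C)nn3-c3ccccc3)c(-c3ccccc3O)c2C#N)cc1` with 3100 nM as its value
compound 2 `CCc1ccc(-c2nc3c(c(C)nn3-c3ccccc3)c(-c3ccccc3[N+](=O)[O-])c2C#N)cc1` with 1200 nM as its value
compound 3 `CCc1ccc(-c2nc3c(c(C)nn3-c3ccccc3)c(-c3ccccc3F)c2C#N)cc1` with 1700 nM as its value

Compound 3 sits close to both other compounds on these numbers. The two gaps that reach it are a 1.8-fold lower number from compound 1 to compound 3 (0.26 log units; within the scatter) and a 1.4-fold higher number from compound 2 to compound 3 (0.15 log units; within the scatter) and neither separates it from the others.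

Compound 4 `CCc1ccc(-c2nc3c(c(C)nn3-c3ccccc3)c(-c3ccccc3C)c2C#N)cc1` has not been measured yet. It has methyl in place of fluoro on an aromatic carbon and nothing else differs.

The closest evidence is the set of swaps at that same carbon. Besides the two gaps above, there is a 2.6-fold lower number from compound 1 to compound 2 (0.41 log units; beyond the scatter) and this modest step is the largest seen. Going by the values given here, none of the measured compounds carries methyl there, so the data give no direction for this swap. In this assay no step beyond the scatter is expected. The estimated step is a 1.1-fold lower number from compound 3 to compound 4 (0.05 log units; within the scatter) and it rests on those small steps. For compound 4 the estimated value is 1500 nM with an expected range from 750 nM to 3000 nM across repeat measurements.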

Compound 4, solubility: 6000 nM
Compound 4: middle estimate off by 4.0-fold (0.60 log units), on the low side; the whole stated range lies below it.
By their numbers in this assay, from the lowest: compounds 2, 3, 1 and 4 (each within the scatter of the next, the first and the last beyond it).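

In this assay, methyl opens the widest gaps yet seen at this aromatic carbon: a 3.5-fold higher number from compound 3 to compound 4 (0.55 log units; beyond the scatter) and a 5.0-fold higher number from compound 2 to compound 4 (0.70 log units; beyond the scatter) are both larger than any step among the hydroxy, nitro and fluoro compounds. Exchanging fluoro for methyl swaps one heavy atom for another, with no hydrogen-bond donor or acceptor counted on either side, yet that is enough to carry the number beyond the scatter. In contrast, a 1.9-fold higher number from compound 1 to compound 4 (0.29 log units; within the scatter) leaves those two compounds unseparated, and nothing available here accounts for the gap between the fluoro and methyl compounds.

An amine, a carboxylic acid or a longer chain such as ethyl at this carbon could land near methyl or near fluoro, and the compounds shown do not tell which. As far as these compounds go, it also remains open whether the gap between fluoro and methyl would persist with other groups on the shared core.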